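Swapping an ester for a nitrophenyl ketone on a diaminopyrazole azo dye

The source may hold more compounds than are shown below. What is called first, only, known or untested is meant among the compounds shown, and "the series" means these compounds.

Compound 1, `CCOC(=O)n1nc(N)c(/N=N/c2ccc(O)cc2)c1N`. In a functional assay on MCF7 cells (Homo sapiens) for cytotoxicity, read by fluorescence, with a stated time of 72 h (a higher number here means a weaker inhibitor, a lower number a stronger inhibitor), compound 1 gives > 100000 nM, which is a limit of the assay rather than a number.
Compound 2, `Nc1n[nH]c(N)c1/N=N/c1cc[n+]([O-])cc1`. In this assay compound 2 gives > 100000 nM, again a limit of the assay.
Compound 3, `Cn1nc(N)c(/N=N/c2ccncc2)c1N`. In this assay compound 3 gives 37700 nM.

Compound 1 therefore stands at the limit of > 100000 nM in this assay, at which 2 of the 3 values shown sit; it has not produced a number of its own, only a boundary that it lies beyond. Among the measured compounds shown here, compound 2 shares that boundary, while compound 3 is the one member of the set that returns a measured concentration.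

The unmeasured compound 4, `Nc1nn(C(=O)c2ccc([N+](=O)[O-])cc2)c(N)c1/N=N/c1ccc(O)cc1`, keeps the shared core of compound 1 and changes one substituent: 4-nitrophenyl in place of ethoxy on a carbonyl carbon. For the measured compounds named here, no step between two measured compounds is available to calibrate what such a swap does here, so the expectation rests on the three values alone. The step from compound 1 to compound 4 is expected to be small and, if anything, in the direction of a stronger inhibitor, amounting to an at least 1.4-fold lower number from compound 1 to compound 4 (0.15 log units; that floor lies within the scatter) in this assay. Compound 4 is estimated to give 70000 nM, within a range from 20000 nM to 250000 nM, with a real chance that the assay again reports only a limit.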

Compound 4, half-maximal inhibitory concentration: > 25000 nM
Compound 4: a limit, no number; the forecaster's own chance of this, stated with the estimate: 45%; the middle value lies beyond the limit too.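

In this assay, compound 1 and compound 4 both return limits rather than numbers, and the step between them cannot be read. The compounds shown leave open whether 4-nitrophenyl in place of ethoxy on a carbonyl carbon changes the result in this assay at all, and if so, in which direction and by how much.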